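A few compounds are considered here, and "the series" means these few. Any claim that something is new, unique, unknown or untested is made for them only; others in the source may bear on it.

In an ADME assay on K562 cells (Homo sapiens) for cytotoxicity, with a stated time of 72 h (a lower number here means a stronger inhibitor, a higher number a weaker inhibitor), compound 3 `COc1ccc(CNc2ncnc3c2ncn3C2CCCO2)cc1` gives > 100000 nM, which is a limit and not a number. Compound 2 `COc1ccccc1CNc1ncnc2c1ncn2C1CCCO1` gives > 100000 nM, also a limit. Compound 1 `COc1ccc(CNc2ncnc3c2ncn3C2CCCCO2)c(OC)c1`, which also carries two methoxy groups, gives > 25000 nM, again a limit. The readings therefore fall at the limit of > 100000 nM in this assay, at which 2 of the 3 values shown sit, and at the limit of > 25000 nM in this assay, at which 1 of the 3 values shown sits. Compound 4 `COc1ccc(CNc2ncnc3c2ncn3C2CCCO2)c(OC)c1` departs from compound 3 by one change: methoxy in place of hydrogen on an aromatic carbon. Among the compounds with values here, the only measured step bearing on it, a step that the two limits leave unreadable from compound 2 to compound 3, moves a methoxy group and gives no readable size. On that basis, no step beyond the scatter is expected in this assay. Compound 4 is estimated at 100000 nM, within an expected range of 30000 nM to 200000 nM. The expected step is a number no higher from compound 3 to compound 4 (the limit leaves the size open).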

Compound 4, half-maximal inhibitory concentration: > 100000 nM
Compound 4 ended at the assay's limit; the forecaster's own chance of this, stated with the estimate: 85%; the middle value sits exactly at the limit.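

Within the data shown here, no step from compound 1, compound 2 or compound 3 to compound 4 can be read in this assay, as all four results are limits and not numbers. The compounds shown leave open whether any of these changes shifts the inhibitory concentration at all.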